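Methylsulfanyl for Dimethylamino on the Pendant Aromatic Ring

A few compounds are considered here, and "the series" means these few. Any claim that something is new, unique, unknown or untested is made for them only; others in the source may bear on it.

Three compounds share a core bearing a hydroxymethyl group flanked by a tert-butyl and an isopropyl substituent, with a second six-membered aromatic ring attached. Compound 1 `COc1ccccc1-c1cc(C(C)(C)C)cc(C(C)C)c1CO` carries a methoxy group on that ring; compound 2 `CC(C)c1cc(C(C)(C)C)cc(-c2cccc(N(C)C)c2)c1CO` carries a dimethylamino group; compound 3 `Cc1ccc(-c2cc(C(C)(C)C)cc(C(C)C)c2CO)cc1` carries a methyl group. In a functional assay on RKE cells for antagonist activity at Vasoactive intestinal polypeptide receptor 1 (Rattus norvegicus), read by HTRF and cAMP accumulation, with stated times of 10 min and 30 min (a lower number here means a stronger inhibitor, a higher number a weaker inhibitor), compound 1 gives 820 nM, compound 2 gives 310 nM, and compound 3 gives 300 nM. Compound 2 thus stands second highest of the three numbers; its value and that of compound 3 lie within the scatter of each other, while compound 1 sits beyond the scatter at a higher number.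

Compound 4 `CSc1cccc(-c2cc(C(C)(C)C)cc(C(C)C)c2CO)c1` is not yet measured. It differs from compound 2 in one place: methylsulfanyl in place of dimethylamino on an aromatic carbon. Among the compounds with values here, no step between measured compounds matches this change, so the expectation rests on the closeness of compound 2 and compound 3, which suggests that small groups at this position are tolerated without much movement in this assay. The step from compound 2 to compound 4 is therefore expected to be a 1.1-fold higher number from compound 2 to compound 4 (0.05 log units; within the scatter), with no direction beyond the scatter claimed. Compound 4 is estimated at 350 nM, within a range from 150 nM to 800 nM.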

Compound 4, half-maximal inhibitory concentration: 170 nM
Estimate against measurement, compound 4: 2.1-fold (0.31 log units) above; low and high end bracket the measured number.
By their numbers in this assay, from the lowest: compounds 4, 3 and 2 (each within the scatter of the next); then compound 1.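

Within the data shown here, the step from dimethylamino to methylsulfanyl on this aromatic carbon gives the first direct reading at this position in this assay: a 1.8-fold lower number from compound 2 to compound 4 (0.26 log units; within the scatter). The earlier compounds shown here differed in more than one place and offered no such single-change comparison, whereas this pair isolates the exchange of a group of 3 heavy atoms, including nitrogen, for one of 2 heavy atoms, including sulfur, with the count of hydrogen-bond donors and acceptors unchanged. Because the step stays within the scatter, the pair shows that this position tolerates the exchange in this assay but supports no claim of a gain, and nothing shown speaks to the reason for the result.

The compounds shown leave open how a primary amine, a carboxylic acid or a longer chain such as ethylsulfanyl would read on the same aromatic carbon. Among these compounds, with only this one step available, they also leave open whether the same exchange would read alike on another aromatic carbon or with other groups on the shared core.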